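Cytotoxicity of aryl-urea quinolines: step to compound 4

This account rests on a few compounds, and the source may have more. Where it says the series, first, only, none or still open, it means among the compounds named here.

Measured compounds:
- compound 1 `Cc1cc(NC(=O)Nc2ccc(C)c(Cl)c2)c2ccccc2n1`; in an ADME assay on BJ cells (Homo sapiens) for cytotoxicity, with a stated time of 72 h (on this read-out higher numbers stand for an effect only at larger amounts of compound and lower numbers for an effect already at smaller amounts), compound 1 gives > 25000 nM, which is a limit of the assay.
- compound 2 `Cc1cc(NC(=O)Nc2ccc(F)cc2)c2ccccc2n1`; in this assay compound 2 gives > 25000 nM, also a limit of the assay.
- compound 3 `COC(=O)c1ccc(NC(=O)Nc2cc(C)nc3ccccc23)cc1`; in this assay compound 3 gives 21000 nM.

Going by the values given here, compound 3 is the only member of the set with a number rather than a limit, and that number sits close to the limit of > 25000 nM in this assay, at which 2 of the 3 values shown sit. Among the compounds with values here, the single measured step, an at least 1.1-fold lower number from compound 2 to compound 3 (0.07 log units; that floor lies within the scatter), lies within the scatter, so the set shows no change in cytotoxicity beyond noise.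

Compound 4 `Cc1cc(NC(=O)Nc2ccc(C(C)(C)C)cc2)c2ccccc2n1` differs from compound 3 by tert-butyl in place of methoxycarbonyl on an aromatic carbon. Within the data shown here, no measured step covers this change; the only information is that two of three compounds reach the limit and the third stands just under it. The expectation for compound 4 in this assay is therefore no step beyond the scatter, with the result likely to be a limit again. The estimated step is a 1.1-fold higher number from compound 3 to compound 4 (0.06 log units; within the scatter). Compound 4 is expected to give 24000 nM, within 11000 nM to 50000 nM.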

Compound 4, half-maximal effective concentration: 20000 nM
Beside the measured number, compound 4's estimate is 1.2-fold (0.08 log units) above it; measured number inside the range.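

The exchange of methoxycarbonyl for tert-butyl on this aromatic carbon gives a 1.1-fold lower number from compound 3 to compound 4 (0.02 log units; within the scatter) in this assay, so a group with no hydrogen-bond acceptors stands level with one that carries them. Against fluoro at the same place, the reading is an at least 1.2-fold lower number from compound 2 to compound 4 (0.09 log units; that floor lies within the scatter), and this is only a floor. A measured number close to the limit is therefore not tied to methoxycarbonyl, yet the limit still bounds what the set can show: the limit of > 25000 nM in this assay, at which 2 of the 4 values shown sit.

As far as these compounds go, whether a carboxylic acid or an amine at this position would move the number beyond the scatter remains open. Also open is how a change to the shared core, such as a longer chain in place of its methyl, would read, as all compounds shown keep that core unchanged.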